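Cyanophenyl Position Swap on a Demethylated Core

This account rests on a few compounds, and the source may have more. Where it says the series, first, only, none or still open, it means among the compounds named here.

Measured so far in a toxicity assay on MT4 cells (Homo sapiens) for cytotoxicity, read by MTT assay; a lower number here means that less compound is tolerated, a higher number that more compound is tolerated:
- compound 1, `Cc1cc(-c2ccccc2C#N)cc(C)c1Oc1cc(N)nc(Nc2ccc(C#N)cc2)n1`: compound 1 gives 25400 nM
- compound 2, `Cc1cc(-c2cccc(C#N)c2)cc(C)c1Oc1cc(N)nc(Nc2ccc(C#N)cc2)n1`: compound 2 gives 20200 nM
- compound 3, `Cc1cc(-c2ccccc2C#N)ccc1Oc1cc(N)nc(Nc2ccc(C#N)cc2)n1`: compound 3 gives 28600 nM

Compound 2 differs from compound 1 by 3-cyanophenyl in place of 2-cyanophenyl on an aromatic carbon, and this change gave a 1.3-fold lower number from compound 1 to compound 2 (0.10 log units; within the scatter). Compound 3 differs from compound 1 in its core by hydrogen in place of methyl on an aromatic carbon, a step that stayed within the scatter, a 1.1-fold higher number from compound 1 to compound 3 (0.05 log units; within the scatter). Compound 4, `Cc1cc(-c2cccc(C#N)c2)ccc1Oc1cc(N)nc(Nc2ccc(C#N)cc2)n1`, differs from compound 3 by 3-cyanophenyl in place of 2-cyanophenyl on an aromatic carbon. This is the same kind of change as that from compound 1 to compound 2, though the place is not identical: in the first case it is meta to two methyl groups, here meta to a methyl group. For compound 4 the expected step is a 1.2-fold lower number from compound 3 to compound 4 (0.09 log units; within the scatter), resting on the earlier 1.3-fold lower number from compound 1 to compound 2 (0.10 log units; within the scatter) from compound 1 to compound 2. Compound 4 is therefore estimated at 23000 nM, with a range from 12000 nM to 45000 nM.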

Compound 4, half-maximal cytotoxic concentration: 27400 nM
For compound 4 the middle estimate is 1.2-fold (0.08 log units) below the measured one; the measured number falls inside the stated range.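

In this assay, 3-cyanophenyl in place of 2-cyanophenyl gives a 1.0-fold lower number from compound 3 to compound 4 (0.02 log units; within the scatter), and hydrogen in place of methyl gives a 1.4-fold higher number from compound 2 to compound 4 (0.13 log units; within the scatter). The cyanophenyl swap reads alike on the two cores: the same change on two cores in this assay, a 1.3-fold lower number (0.10 log units; within the scatter) from compound 1 to compound 2 and a 1.0-fold lower number (0.02 log units; within the scatter) from compound 3 to compound 4, 1.2-fold (0.08 log units) apart, within the scatter of two such steps The methyl swap reads alike too, but since every step here lies within the scatter, this shows only that neither change stands out on these cores, not that a larger step would carry over equally well: the same change on two cores in this assay, a 1.1-fold higher number (0.05 log units; within the scatter) from compound 1 to compound 3 and a 1.4-fold higher number (0.13 log units; within the scatter) from compound 2 to compound 4, 1.2-fold (0.08 log units) apart, within the scatter of two such steps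

Going by these compounds, it remains open whether a step beyond the scatter would transfer between these cores. On these data alone, it is also open whether an amine or a carboxylic acid in place of the nitrile would shift this number.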